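Changing the ring on the amide nitrogen: cytotoxicity expectations

A few compounds are considered here, and "the series" means these few. Any claim that something is new, unique, unknown or untested is made for them only; others in the source may bear on it.

Within the data shown here, compound 2 `Cc1cccc(NC(=O)CSc2snnc2-c2ccc(Br)cc2Br)c1C` is the only compound of the three that gives a plain number in an ADME assay on MT4 cells (Homo sapiens) for cytotoxicity, read by MTT assay, with a stated time of 5 days; on this read-out higher numbers stand for lower toxicity in this test and lower numbers for higher toxicity in this test: compound 2 gives 241000 nM. Compound 1 `O=C(CSc1snnc1-c1ccc(Br)cc1Br)Nc1ccccc1F` reaches only a limit of the test, >= 27800 nM. Compound 3 `CC(=O)c1ccc(NC(=O)CSc2snnc2-c2ccc(Br)cc2Br)c(Br)c1` likewise stops at a limit, > 206000 nM. Only one step between measured compounds is shown, a step that the limit leaves unreadable from compound 1 to compound 2, and it stays unreadable because of the limit of >= 27800 nM in this assay, at which 1 of the 3 values shown sits. Compound 4 `O=C(CSc1snnc1-c1ccc(Br)cc1Br)Nc1ccc(Cl)cc1` differs from compound 2 by 4-chlorophenyl in place of 2,3-dimethylphenyl on an amide-type nitrogen. No readable step bears on this change, so no shift beyond the usual scatter is expected. Compound 4 is therefore expected to give about 200000 nM, somewhere between 60000 nM and 500000 nM. This amounts to an expected step of a 1.2-fold lower number from compound 2 to compound 4 (0.08 log units; within the scatter).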

Compound 4, half-maximal cytotoxic concentration: 23300 nM
For compound 4 the middle estimate is 8.6-fold (0.93 log units) above the measured one; the whole stated range lies above it.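

Among these compounds, the first readable step at this place is a 10-fold lower number from compound 2 to compound 4 (1.01 log units; beyond the scatter) in this assay, so 4-chlorophenyl on the amide-type nitrogen goes with higher toxicity in this test than 2,3-dimethylphenyl. Against 2-fluorophenyl the change gives an at least 1.1-fold lower number from compound 1 to compound 4 (0.07 log units; that floor lies within the scatter), and this step has only a floor because of a limit: the limit of >= 27800 nM in this assay, at which 1 of the 4 values shown sits.

The other steps at this place cannot be read. Going by these compounds, whether the chlorine or the loss of the two methyl groups matters more stays open, as does the effect of an amine or a carboxylic acid on this ring.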